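The source may report more compounds than this note shows. Statements on the series, on what has been measured and on what is new or still open speak of the compounds shown alone.

Measured so far in a functional assay on PC-3 cells (Homo sapiens) for cytotoxicity, read by MTT assay, with a stated time of 48 h; on this read-out lower numbers stand for stronger inhibition and higher numbers for weaker inhibition: compound 1 `Cc1nc(-c2c[nH]c3ccccc23)co1` gives 337000 nM; compound 2 `Clc1ccc(-c2nc(-c3c[nH]c4ccccc34)co2)cc1` gives 151000 nM; compound 3 `C=Cc1nc(-c2c[nH]c3ccccc23)co1` gives 426000 nM.

Compound 2 has the lowest number of the three. The steps seen so far, a 2.2-fold lower number from compound 1 to compound 2 (0.35 log units; beyond the scatter) and a 2.8-fold higher number from compound 2 to compound 3 (0.45 log units; beyond the scatter), both concern the group on an aromatic carbon of the shared core, while a 1.3-fold higher number from compound 1 to compound 3 (0.10 log units; within the scatter) lies within the scatter. Among the compounds with values here, compound 4 `Cn1cc(-c2coc(-c3ccc(Cl)cc3)n2)c2ccccc21` differs from compound 2 by methyl in place of hydrogen on an aromatic nitrogen, a change at a place none of the measured steps touches. Within the data shown here, no measured step therefore bears on it, and no step beyond the scatter is expected in this assay . Compound 4 is accordingly estimated at 150000 nM, within 50000 nM to 450000 nM, an expected step of a 1.0-fold lower number from compound 2 to compound 4 (0.00 log units; within the scatter).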

Compound 4, half-maximal inhibitory concentration: 302000 nM
Compound 4: the middle estimate sits 2.0-fold (0.30 log units) below what was measured; measured number inside the range.
By their numbers in this assay, from the lowest: compounds 2, 4, 1 and 3 (each within the scatter of the next, the first and the last beyond it).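

Methyl in place of hydrogen on the aromatic nitrogen, the first change at this position, gives a 2.0-fold higher number from compound 2 to compound 4 (0.30 log units; within the scatter) in this assay. Compound 2 and compound 4 therefore cannot be told apart on this read-out, so with 4-chlorophenyl on the core, the hydrogen on this nitrogen is not shown to matter. No measurement shown accounts for this result. As far as these compounds go, whether a longer chain such as butyl, or a benzyl group, would fit on this nitrogen stays open. So does whether methyl there would give the same result with vinyl on the core.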